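A Sulfonium Side Chain on a Chromanol Core

The source may hold more compounds than are shown below. What is called first, only, known or untested is meant among the compounds shown, and "the series" means these compounds.

Measured compounds:
compound 1, `Cc1c(C)c2c(c(C)c1O)CCC(C)(C(=O)[N-][N+](C)(C)C)O2`: 14000 nM
compound 2, `CCCCCCCCCCCCCCCCCCOC1=C(O)[C@@H](C(O)CO)OC1=O`: 6000 nM

Both compounds were tested in a functional assay (brain) for inhibition, with Rattus norvegicus as the target; on this read-out higher numbers stand for weaker inhibition and lower numbers for stronger inhibition. Compound 1 gives 14000 nM and holds the higher of the two values. Compound 2 gives 6000 nM, a lower number, and the gap between the two lies beyond the usual scatter. The two structures differ in many places at once, so nothing about any single structural change can be read from that pair.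

Compound 3, `Cc1c(C)c2c(c(C)c1O)CCC(C)(CC[S+](C)C)O2`, has not yet been measured in this assay. It keeps the core of compound 1 and differs from it in one place: a group of 5 heavy atoms (4 carbon, 1 sulfur; no ring) in place of a group of 7 heavy atoms (4 carbon, 2 nitrogen, 1 oxygen; no ring), on a saturated ring carbon. For the measured compounds named here, no measured pair shows the effect of this exchange, so the expectation rests on compound 1 alone. With the core kept, the value of compound 3 is expected to stay close to that of compound 1, and the step estimated as a 1.4-fold lower number from compound 1 to compound 3 (0.15 log units; within the scatter) means no change beyond the scatter. Compound 3 is estimated to give 10000 nM, within a range from 3000 nM to 40000 nM.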

Compound 3, half-maximal inhibitory concentration: 2000 nM
For compound 3 the middle estimate is 5.0-fold (0.70 log units) above the measured one; measured number outside the range, below it.
By their numbers in this assay, from the lowest: compound 3; then compound 2; then compound 1.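

In this assay, the exchange on the saturated ring carbon next to the ring oxygen produces a 7.0-fold lower number from compound 1 to compound 3 (0.85 log units; beyond the scatter), so what sits at this position does matter for the read-out, something the first two compounds, which differ in many places at once, could not show. The exchange changes several counted features together: the group that enters has 5 heavy atoms including sulfur, a net charge of +1 and no hydrogen-bond acceptor, while the group that leaves has 7 heavy atoms including two nitrogens and one oxygen, no net charge, one double bond and 1 hydrogen-bond acceptor, so this single step cannot say which of these differences counts. Nothing available here measures why the number falls with this exchange.

Still open, going by these compounds, is whether the sulfur itself is needed or whether the net charge on a chain of this kind would be enough, a question that a chain ending in an amine at the same ring carbon could help to settle. On these data alone, the effect of chain length is equally open, and a longer chain ending in the same sulfur group would test it.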